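From compound 2 to compound 4: working notes

The source may hold more compounds than are shown below. What is called first, only, known or untested is meant among the compounds shown, and "the series" means these compounds.

In a physicochemical assay for solubility, in phosphate buffer, measured as kinetic solubility (a higher number here means a more soluble compound, a lower number a less soluble compound), compound 1 `CC(C)[C@@H](c1ccc(-c2ccc3cccc(F)c3c2)[nH]c1=O)[C@@H]1OC(=O)NC1=O` gives 27400 nM and compound 3 `O=C1NC(=O)/C(=C/C(c2ccc(-c3ccc4cccc(F)c4c3)[nH]c2=O)C2CC2)O1` gives 30800 nM. Compound 2 `CC(C)C(c1ccc(-c2ccc3cccc(F)c3c2)[nH]c1=O)C1NC(=O)NC1=O` stands lowest of the three at 10600 nM, beyond the scatter from both others. Compound 4 `CC(C)C(/C=C1\SC(=O)NC1=O)c1ccc(-c2ccc3cccc(F)c3c2)[nH]c1=O` differs from compound 2 in one place: a group of 8 heavy atoms (4 carbon, 1 nitrogen, 2 oxygen, 1 sulfur; one five-membered non-aromatic ring with 2 hetero atoms) in place of a group of 7 heavy atoms (3 carbon, 2 nitrogen, 2 oxygen; one five-membered non-aromatic ring with 2 hetero atoms), on a saturated chain carbon bound to an aromatic carbon and a saturated chain carbon. For the measured compounds named here, no measured pair isolates this change, so the guide is weak. The expectation rests on the three values alone, and two of them, compound 1 at 27400 nM and compound 3 at 30800 nM, lie above compound 2. A moderate upward move is expected in this assay, estimated as a 2.3-fold higher number from compound 2 to compound 4 (0.35 log units; beyond the scatter). The estimated value for compound 4 is 24000 nM, with an expected range of 9000 nM to 50000 nM.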

Compound 4, solubility: 25600 nM
Compound 4: the middle estimate sits 1.1-fold (0.03 log units) below what was measured; measured number inside the range.
By their numbers in this assay, from the lowest: compound 2; then compounds 4, 1 and 3 (each within the scatter of the next).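

At this place, on a saturated chain carbon bound to an aromatic carbon and a saturated chain carbon, replacing 2,5-dioxoimidazolidin-4-yl gives a 2.4-fold higher number from compound 2 to compound 4 (0.38 log units; beyond the scatter) in this assay. For the compounds shown here, this is the first single-place step, and it shows that exchanging one five-membered non-aromatic ring for another can move the read-out beyond the scatter. Nothing available assigns the step to any feature of the entering group.
As far as these compounds go, how a carboxylic acid or an amine at the same place would compare remains open. So does whether the step holds on other parts of the shared core.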